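The compounds below may be only part of what the source reports. "The series", "measured", "known", "first", "only" and "open" are said of these compounds alone.

Compound 1 `COc1ccc2c(=O)c(/C=C/C(=O)Nc3ccccc3)coc2c1`: in a functional assay (QGY7701 cells, Homo sapiens) for inhibition, read by MTT assay, with a stated time of 48 h (a higher number here means a weaker inhibitor, a lower number a stronger inhibitor), compound 1 gives 14000 nM.
Compound 2 `COc1ccc2c(=O)c(/C=C/C(=O)Nc3cc(C)ccc3C)coc2c1`: in this assay compound 2 gives > 100000 nM, which is a limit of the assay and not a number.

Compound 2 therefore stands at the edge of what the numbers show: all that is known of it is the limit of > 100000 nM in this assay, at which 1 of the 2 values shown sits, and its distance from compound 1 is itself only a bound, an at least 7.1-fold higher number from compound 1 to compound 2 (0.85 log units; beyond the scatter). Compound 3 `COc1cccc(NC(=O)/C=C/c2coc3cc(OC)ccc3c2=O)c1` differs from compound 2 in one place: 3-methoxyphenyl in place of 2,5-dimethylphenyl on an amide-type nitrogen. Going by the values given here, the only measured step that bears on this change is an at least 7.1-fold higher number from compound 1 to compound 2 (0.85 log units; beyond the scatter), where 2,5-dimethylphenyl entered in place of phenyl. Taking the 2,5-dimethylphenyl away again and setting a 3-methoxyphenyl on the amide-type nitrogen is expected to bring the number back down from the limit, though the size of that return cannot be fixed from one bounded step. For compound 3 the expected step is an at least 4.0-fold lower number from compound 2 to compound 3 (0.60 log units; beyond the scatter). The estimate for compound 3 in this assay is 25000 nM, with a range from 8000 nM to 100000 nM.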

Compound 3, half-maximal inhibitory concentration: 39100 nM
For compound 3 the middle estimate is 1.6-fold (0.19 log units) below the measured one; the range from low to high includes it.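

In this assay, a substituted phenyl on the amide-type nitrogen need not reach the limit: 3-methoxyphenyl in place of 2,5-dimethylphenyl gives an at least 2.5-fold lower number from compound 2 to compound 3 (0.40 log units; beyond the scatter) and returns a real number. Going by these compounds alone, the plain phenyl of compound 1 is still not matched, since methoxy in place of hydrogen on an aromatic carbon gives a 2.8-fold higher number from compound 1 to compound 3 (0.45 log units; beyond the scatter) and so provides the first step at this position with a definite size. The step from the dimethyl compound remains only a bound, because compound 2 is known solely by a limit: the limit of > 100000 nM in this assay, at which 1 of the 3 values shown sits.

On these data alone, whether any substituent on this phenyl can bring the number below that of compound 1 remains open. So does whether the change follows from methoxy itself or from its place on the ring, and a hydroxyl, an amine or a carboxylic acid there would bear on that question.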